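Four analogues on U-251 cells: chloro, nitro and position

The source may report more compounds than this note shows. Statements on the series, on what has been measured and on what is new or still open speak of the compounds shown alone.

Four compounds share one core and differ only in the aromatic ring attached to the carbon with a double bond to nitrogen. Compound 1 `CC1=CC[C@H](C(C)(C)NC(=S)N/N=C/c2ccccc2Cl)CC1` carries a 2-chlorophenyl group there; in a functional assay on U-251 cells (Homo sapiens) for inhibition, read by sulforhodamine B assay, with a stated time of 48 h (a lower number here means a stronger inhibitor of growth, a higher number a weaker inhibitor of growth), compound 1 gives only a limit, > 100000 nM. Compound 2 `CC1=CC[C@H](C(C)(C)NC(=S)N/N=C/c2cccc(Cl)c2)CC1` differs from compound 1 in that (3-chlorophenyl in place of 2-chlorophenyl on a carbon with a double bond to nitrogen), and in this assay compound 2 gives 35800 nM, which is an at least 2.7-fold lower number from compound 1 to compound 2 (0.44 log units; beyond the scatter). Compound 3 `CC1=CC[C@H](C(C)(C)NC(=S)N/N=C/c2ccccc2[N+](=O)[O-])CC1` differs from compound 1 in that (nitro in place of chloro on an aromatic carbon); in this assay compound 3 again reaches only a limit, > 100000 nM. This gives a step that the two limits leave unreadable from compound 1 to compound 3, unreadable because of the limit of > 100000 nM in this assay, at which 2 of the 3 values shown sit. Compound 4 `CC1=CC[C@H](C(C)(C)NC(=S)N/N=C/c2cccc([N+](=O)[O-])c2)CC1` awaits measurement; it differs from compound 2 in that (nitro in place of chloro on an aromatic carbon), the same kind of change as from compound 1 to compound 3, yet here made meta to a large group rather than ortho to a large group. The earlier step offers no readable size, so the expectation rests on compound 2 and its value of 35800 nM. Compound 4 is therefore estimated at 50000 nM, within 15000 nM to 200000 nM, an expected 1.4-fold higher number from compound 2 to compound 4 (0.15 log units; within the scatter).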

Compound 4, concentration for total growth inhibition: > 100000 nM
Compound 4: a limit, no number (the forecaster's own chance of this, stated with the estimate: 35%); middle value at least 2.0-fold (0.30 log units) away from the limit.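

In this assay, from the compounds shown here alone, nitro in place of chloro on an aromatic carbon, meta to a large group, gives an at least 2.7-fold higher number from compound 2 to compound 4 (0.44 log units; beyond the scatter), a loss of growth inhibition beyond the scatter whose full size stays unknown, as compound 4 reaches only a limit. Among the compounds shown here, this is the only readable step for this change, so it shows the change going against activity on one core and cannot show that the same holds on another. The matching steps that start from or end at compound 1 and compound 3 cannot be read, and no comparison of the change between the two cores is possible, because these values sit at a limit: the limit of > 100000 nM in this assay, at which 3 of the 4 values shown sit.

The compounds shown leave open whether another group in the same place, such as an amine or a methoxy group, would match or better compound 2 at 35800 nM. They also leave open whether bromo or fluoro there would track chloro or nitro.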